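Methyl ester of a polyunsaturated keto acid: expected response

The source may report more compounds than this note shows. Statements on the series, on what has been measured and on what is new or still open speak of the compounds shown alone.

Measured compounds:
compound 1 `CCCCC/C=C\C/C=C\C/C=C\C=C\C(=O)CCCC(=O)OC` — 133%
compound 2 `CC/C=C\C/C=C\C/C=C\C/C=C\C=C\C(=O)CCCC(=O)O` — 80%
compound 3 `CC/C=C\C/C=C\C/C=C\C/C=C\C/C=C\C=C\C(=O)CCC(=O)O` — 23%

In a functional assay on cells for agonist activity at Oxoeicosanoid receptor 1 (Homo sapiens), read by beta-arrestin recruitment (on this read-out higher numbers stand for larger maximal responses and lower numbers for smaller maximal responses), compound 1 gives 133%, compound 2 gives 80% and compound 3 gives 23%. Compound 3 thus stands lowest of the three: its nearest neighbour is compound 2, whose value is higher by a gap beyond the scatter, and compound 1 lies further above still. No step between two of these compounds is laid out, so the two esters and acids may only be compared by their plain values, where compound 1, a methyl ester, shows the largest response and the two free acids, compound 2 and compound 3, the smaller ones.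

The unmeasured compound 4 `CC/C=C\C/C=C\C/C=C\C/C=C\C/C=C\C=C\C(=O)CCC(=O)OC` differs from compound 3 by methyl in place of hydrogen on an oxygen next to a carbonyl group. Given that compound 1 gives 133% while compound 3 gives 23%, an upward step from compound 3 to compound 4 is expected, likely beyond the scatter, estimated as a number 42 percentage points higher from compound 3 to compound 4 (beyond the scatter). Compound 4 is therefore expected to reach about 65%, with a range from 30% to 110%.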

Compound 4, largest response reached (Emax), in percent of the reference or control that the assay uses: 64%
Beside the measured number, compound 4's estimate is 1 percentage points above it, and the stated range covers the measured number.
By their numbers in this assay, from the lowest: compound 3; then compound 4; then compound 2; then compound 1.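

In this assay, the change from carboxy to methoxycarbonyl, with methyl in place of hydrogen on an oxygen next to a carbonyl group, gives a number 41 percentage points higher from compound 3 to compound 4 (beyond the scatter), a large step. Earlier, esters and acids could be set side by side only by their plain values, whereas this pair differs in one place alone, so the rise can be tied to this single change on this core. The entering methyl adds just one heavy atom and no hydrogen-bond donors or acceptors, yet no measurement here explains why the response rises.

The compounds shown leave open whether the same change gives a step of similar size on the core of compound 2, and whether an ethyl ester or a primary amide in place of the methoxycarbonyl group would raise the response further. They also leave open whether a tetrazole in place of the carboxy group of compound 3 would give a response closer to that of the acid or of the ester.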